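Fluoro for trifluoromethyl on the pendant aryl of compound 2

A few compounds are considered here, and "the series" means these few. Any claim that something is new, unique, unknown or untested is made for them only; others in the source may bear on it.

Compound 1 `COc1ccc2cc(C(C)c3nnc4n3N=C(c3ccc(OC(F)(F)F)cc3)CS4)ccc2c1` and compound 2 `CC(c1ccc(-c2ccccc2)c(F)c1)c1nnc2n1N=C(c1ccc(C(F)(F)F)cc1)CS2` share one core. In a functional assay on HCT-116 cells (Homo sapiens) for inhibition, read by sulforhodamine B assay, with a stated time of 72 h (on this read-out higher numbers stand for weaker inhibition and lower numbers for stronger inhibition), compound 1 gives 11700 nM and compound 2 gives 6100 nM; the two numbers lie within the usual scatter of each other, so no order between them is claimed. Compound 3 `CC(c1ccc(-c2ccccc2)c(F)c1)c1nnc2n1N=C(c1ccc(F)cc1)CS2` differs from compound 2 by fluoro in place of trifluoromethyl on an aromatic carbon. Within the data shown here, no measured pair shows this change, so the step from compound 2 to compound 3 in this assay is expected to be small, a 1.5-fold higher number from compound 2 to compound 3 (0.17 log units; within the scatter), and not clearly beyond the scatter in either direction. Compound 3 is therefore estimated at 9000 nM, with a range from 3500 nM to 25000 nM.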

Compound 3, half-maximal inhibitory concentration: 10500 nM
For compound 3 the middle estimate is 1.2-fold (0.07 log units) below the measured one; low and high end bracket the measured number.
By their numbers in this assay, from the lowest: compounds 2, 3 and 1 (each within the scatter of the next).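

In this assay, the change from 4-(trifluoromethyl)phenyl to 4-fluorophenyl gives the series its first comparison of compounds differing in one place, with a 1.7-fold higher number from compound 2 to compound 3 (0.24 log units; within the scatter). On this aromatic carbon, para to a large group, the read-out therefore does not separate trifluoromethyl from fluoro. No measured data bear on the reason for this.

Going by these compounds, whether an amine or a carboxylic acid at this position would give a step beyond the scatter remains open. Also open, on these data alone, is whether the same exchange would read alike with a different group on the other side of the core.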